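Isopropylamino in place of anilino at the assay limit

The source may hold more compounds than are shown below. What is called first, only, known or untested is meant among the compounds shown, and "the series" means these compounds.

Compound 1 `CCCc1nn(C)c2c(NCC(C)C)nc(/C=C/c3ccccc3)nc12` gives > 50000 nM in an ADME assay on RAW264.7 cells (Mus musculus) for cytotoxicity (a lower number here means a stronger inhibitor, a higher number a weaker inhibitor), which is a limit and not a number. Compound 2 `CCCc1nn(C)c2c(Nc3ccccc3)nc(/C=C/c3ccccc3)nc12` gives > 50000 nM in this assay, again only a limit. Going by the values given here, compound 2 therefore has no numerical standing, and the series so far reads (the limit of > 50000 nM in this assay, at which 2 of the 2 values shown sit).

Compound 3 `CCCc1nn(C)c2c(NC(C)C)nc(/C=C/c3ccccc3)nc12` comes from compound 2 by isopropyl in place of phenyl on a nitrogen on an aromatic ring, in words anilino to isopropylamino. Among the compounds with values here, the one measured step bearing on this change is a step that the two limits leave unreadable from compound 1 to compound 2, with phenyl in place of isobutyl, and it offers no size to carry over. Compound 1, which carries isobutyl, stands at > 50000 nM, also a limit, so compound 3 is expected to end at the limit too. The expected step that the limit leaves unreadable from compound 2 to compound 3 is no step beyond the scatter in this assay, in either direction. For compound 3 the estimate is 60000 nM, with an expected range of 25000 nM to 100000 nM.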

Compound 3, half-maximal inhibitory concentration: > 50000 nM
Compound 3 gave a limit, no number (the forecaster's own chance of this, stated with the estimate: 85%); the middle value is on the limit's open side.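

No step can be read among compound 1, compound 2 and compound 3 in this assay, as all three sit at the same limit: the limit of > 50000 nM in this assay, at which 3 of the 3 values shown sit.

How far isobutyl, phenyl and isopropyl on the nitrogen differ in cytotoxicity stays open, with no compound shown giving a number.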